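Aminobenzamide to cyclohexylurea on the shared core

A few compounds are considered here, and "the series" means these few. Any claim that something is new, unique, unknown or untested is made for them only; others in the source may bear on it.

Going by the values given here, compound 1 `CCc1cc(S(=O)(=O)N2C[C@H](c3ccccc3)NC2=O)ccc1NC(=O)c1ccc(N)cc1` is the only compound of the set with a number in a functional assay on A549 cells (Homo sapiens) for cytotoxicity, read by MTT assay (on this read-out higher numbers stand for weaker inhibition and lower numbers for stronger inhibition), where compound 1 gives 220 nM. Compound 2 `Cc1cc(S(=O)(=O)N2C(=O)N[C@@H](c3ccccc3)C2C)ccc1NC(=O)c1ccc([N+](=O)[O-])cc1` is reported only as a limit in this assay, > 10000 nM: the limit of > 10000 nM in this assay, at which 1 of the 2 values shown sits. Compound 3 `CCc1cc(S(=O)(=O)N2C[C@H](c3ccccc3)NC2=O)ccc1NC(=O)NC1CCCCC1` differs from compound 1 by cyclohexylamino in place of 4-aminophenyl on a carbonyl carbon. Among the compounds with values here, no pair of measured compounds shows this change, so its size is uncertain. A moderate loss of potency is expected, with the step of a 3.6-fold higher number from compound 1 to compound 3 (0.56 log units; beyond the scatter) likely lying beyond the scatter. For compound 3 the expected value in this assay is 800 nM, between 150 nM and 5000 nM.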

Compound 3, half-maximal inhibitory concentration: 500 nM
Beside the measured number, compound 3's estimate is 1.6-fold (0.20 log units) above it; low and high end bracket the measured number.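

The change from 4-aminophenyl to cyclohexylamino on a carbonyl carbon brings a 2.3-fold higher number from compound 1 to compound 3 (0.36 log units; beyond the scatter) in this assay. This modest step shows that, on the shared core, the place tolerates a non-aromatic ring of carbon in place of the aromatic one, at a measurable cost. Nothing shown gives a reason for this step.

On these data alone, it remains open how an open chain such as n-hexylamino, or a smaller group such as methylamino, would fare at this place. As far as these compounds go, it also remains open whether the amine or the ring of 4-aminophenyl carries its contribution.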